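Third methoxy on the aromatic ring: outlook for compound 3

The source may report more compounds than this note shows. Statements on the series, on what has been measured and on what is new or still open speak of the compounds shown alone.

Measured in a functional assay on MCF7 cells (Homo sapiens) for inhibition, read by sulforhodamine B assay, with a stated time of 48 h; on this read-out lower numbers stand for stronger inhibition of growth and higher numbers for weaker inhibition of growth:
compound 1 `COc1ccc(/C=C/C2CC(=O)C=CO2)cc1`: 156 uM
compound 2 `COc1ccc(/C=C/C2CC(=O)C=CO2)cc1OC`: 130 uM

Compound 2 gives the lower of the two numbers, but compound 1 lies within the scatter of it, so no order between them is claimed. Compound 3 `COc1cc(/C=C/C2CC(=O)C=CO2)cc(OC)c1OC` differs from compound 2 by methoxy in place of hydrogen on an aromatic carbon. Among the compounds with values here, the only step that bears on this change is a 1.2-fold lower number from compound 1 to compound 2 (0.08 log units; within the scatter), which did not move the number beyond the scatter. In this assay no move beyond the scatter is therefore expected for compound 3. The step expected is a 1.1-fold lower number from compound 2 to compound 3 (0.03 log units; within the scatter). For compound 3 the estimate is 120 uM, within a range of 55 uM to 260 uM.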

Compound 3, concentration for growth inhibition (reported as GI): 149 uM
Beside the measured number, compound 3's estimate is 1.2-fold (0.09 log units) below it; measured number inside the range.
By their numbers in this assay, from the lowest: compounds 2, 3 and 1 (each within the scatter of the next).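

In this assay, methoxy in place of hydrogen on this aromatic carbon, ortho to a methoxy group, gives a 1.1-fold higher number from compound 2 to compound 3 (0.06 log units; within the scatter) and so leaves compound 3 unseparated from compound 2. The same change has now stayed within the scatter at two places on the ring, in the only two steps of this kind shown. No available evidence bears on this result. Still open, as far as these compounds go, is whether a group other than methoxy at this place, such as an amine or a carboxylic acid, would move the number beyond the scatter.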